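Hydroxy addition on a macrocyclic diphenol pair

The source may report more compounds than this note shows. Statements on the series, on what has been measured and on what is new or still open speak of the compounds shown alone.

Compound 1 `Oc1ccc2cc1Oc1ccc(cc1)CCc1cccc(O)c1Oc1ccc(cc1)CC2` and compound 2 `Oc1ccc2cc1Oc1ccc(cc1)CCc1cccc(O)c1Oc1ccc(cc1O)CC2` share one core; compound 3 `Oc1ccc2cc1Oc1ccc(cc1)CCc1ccc(O)c(c1)Oc1ccc(cc1)CC2` has the same atoms joined differently, and the difference between the two cores is not broken down here. Compound 4 `Oc1ccc2cc1Oc1ccc(cc1)CCc1ccc(O)c(c1)Oc1ccc(cc1O)CC2` is the counterpart of compound 3 and is not yet measured.

In a functional assay on HeLa cells (Homo sapiens) for antiproliferative activity, read by MTT assay, with a stated time of 48 h (a lower number here means a stronger inhibitor, a higher number a weaker inhibitor), compound 1 gives 10500 nM. Among the compounds with values here, compound 2 gives 27400 nM in this assay, and the step of a 2.6-fold higher number from compound 1 to compound 2 (0.42 log units; beyond the scatter) is the one measured instance of this change: hydroxy in place of hydrogen on an aromatic carbon. Compound 3 gives 22700 nM in this assay; against compound 2 it lies within the scatter, against compound 1 it lies beyond it.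

The change from compound 3 to compound 4 is the same change on the same kind of place: hydroxy in place of hydrogen on an aromatic carbon. Within the data shown here, the two place descriptions agree word for word, so the step seen from compound 1 to compound 2 is the only guide, and it rests on a single pair. For compound 4 the expectation is a step of about a 2.4-fold higher number from compound 3 to compound 4 (0.38 log units; beyond the scatter) in this assay, drawn from the step of a 2.6-fold higher number from compound 1 to compound 2 (0.42 log units; beyond the scatter) applied to the value of compound 3. The estimate for compound 4 in this assay is therefore 55000 nM, with a plausible range from 25000 nM to 120000 nM; the upper end reflects that a weaker number may run toward the top of the measurable range of this assay and be reported only as a limit.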

Compound 4, half-maximal inhibitory concentration: 29500 nM
For compound 4 the middle estimate is 1.9-fold (0.27 log units) above the measured one, within the range that was stated.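

Hydroxy in place of hydrogen on an aromatic carbon now has a second reading in this assay, on the core of compound 3, and the new step is a 1.3-fold higher number from compound 3 to compound 4 (0.11 log units; within the scatter). Set beside the earlier step, the two readings cannot be told apart: the same change on two cores in this assay, a 2.6-fold higher number (0.42 log units; beyond the scatter) from compound 1 to compound 2 and a 1.3-fold higher number (0.11 log units; within the scatter) from compound 3 to compound 4, 2.0-fold (0.30 log units) apart, within the scatter of two such steps. This shows that the two cores give no measurable disagreement for this change and that, in both pairs, the added hydroxy brings no gain in potency; it does not show that the step has one fixed size or that it transfers reliably, as only the earlier step lies beyond the scatter and two pairs are too few to support a rule for the series.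

The compounds shown leave open how other groups on this aromatic carbon would behave, such as a methoxy, an amine or a carboxylic acid in place of the hydroxy. Also open, from the compounds shown here alone, is whether a hydroxy on a different aromatic carbon of either core would give a step of similar size.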